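This account rests on a few compounds, and the source may have more. Where it says the series, first, only, none or still open, it means among the compounds named here.

Compound 1 `O=C(/C=C/c1ccc([N+](=O)[O-])o1)c1ccc(Br)cc1` and compound 2 `O=C(/C=C/c1ccc([N+](=O)[O-])o1)c1ccc(I)cc1` share one core and differ only in a single halogen on one ring. In a functional assay on U-251 cells (Homo sapiens) for inhibition, read by sulforhodamine B assay, with a stated time of 72 h (a lower number here means that less compound is needed, a higher number that more compound is needed for the effect), compound 1 gives 21400 nM, and compound 2 gives 12500 nM. The change between them is iodo in place of bromo on an aromatic carbon, and it brought a 1.7-fold lower number from compound 1 to compound 2 (0.23 log units; within the scatter).

Compound 3 `COc1ccc(/C=C/C(=O)c2cccc(Br)c2)cc1` rests on a different core; how that core differs from the core of compound 1 is not broken down here. In this assay compound 3 gives 32100 nM. Set beside the other two, the number of compound 3 and that of compound 1 lie within the usual scatter of each other, while the number of compound 2 lies beyond the scatter, on the lower side.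

Compound 4 `COc1ccc(/C=C/C(=O)c2cccc(I)c2)cc1` has not yet been measured. It differs from compound 3 by iodo in place of bromo on an aromatic carbon. Going by the values given here, this is the same kind of change as the one from compound 1 to compound 2, though not the same: there the place was para to a large group, here it is meta to a large group. Among the compounds with values here, only one example of this change has been measured, and that one stayed within the scatter. The step from compound 3 to compound 4 is therefore expected to be of similar size, a 1.7-fold lower number from compound 3 to compound 4 (0.23 log units; within the scatter), because the earlier step gave a 1.7-fold lower number from compound 1 to compound 2 (0.23 log units; within the scatter). In this assay compound 4 is estimated at 19000 nM, with a likely range from 9000 nM to 40000 nM.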

Compound 4, half-maximal effective concentration: 21400 nM
Beside the measured number, compound 4's estimate is 1.1-fold (0.05 log units) below it; measured number inside the range.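

In this assay, placing iodo where bromo stood on the core of compound 3 gave a 1.5-fold lower number from compound 3 to compound 4 (0.18 log units; within the scatter). Set beside the same change on the core of compound 1, the two results agree: the same change on two cores in this assay, a 1.7-fold lower number (0.23 log units; within the scatter) from compound 1 to compound 2 and a 1.5-fold lower number (0.18 log units; within the scatter) from compound 3 to compound 4, 1.1-fold (0.06 log units) apart, within the scatter of two such steps. This shows that the swap from bromo to iodo behaved alike on two different cores, and at two different places on a six-membered ring, giving a small step each time; it does not show that iodo and bromo truly differ in this assay, for each step on its own is no larger than the differences expected between repeated measurements, and two pairs cannot establish how the change will behave on a further core.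

The compounds shown carry only bromo or iodo at these places, which leaves open how either core would respond to a lighter halogen such as fluoro or chloro, or to a quite different group such as an amine or a carboxylic acid. All the numbers also come from a single test in one type of cell, so whether the two halogens stay this close in other cells remains an open question.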